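The source may hold more compounds than are shown below. What is called first, only, known or untested is meant among the compounds shown, and "the series" means these compounds.

In a functional assay on NCI-H226 cells (Homo sapiens) for cytotoxicity, read by sulforhodamine B assay, with a stated time of 48 h, tested at 10 uM (on this read-out lower numbers stand for a stronger effect and higher numbers for a weaker effect at the one concentration tested), compound 1 `COc1cc(-c2cc(/C=C/C(=O)c3ccc(Cl)c(Cl)c3)[nH]n2)cc(OC)c1OC` gives 67% and compound 2 `COc1ccc(C(=O)/C=C/c2cc(-c3cc(OC)c(OC)c(OC)c3)n[nH]2)cc1OC` gives -81%, the lowest of the two numbers; the step of a number 148 percentage points lower from compound 1 to compound 2 (beyond the scatter) is large. Compound 3 `COc1cc(-c2cc(/C=C/C(=O)c3ccc(F)c(F)c3)[nH]n2)cc(OC)c1OC` differs from compound 2 by 3,4-difluorophenyl in place of 3,4-dimethoxyphenyl on a carbonyl carbon. Going by the values given here, the only step that bears on this change is the one from compound 1 to compound 2, which runs in the opposite sense (a halogenated ring replaced by the dimethoxy ring), so a rise in this assay of comparable size is expected, with an expected step of a number 131 percentage points higher from compound 2 to compound 3 (beyond the scatter). Compound 3 is therefore estimated at 50%, within a range from 5% to 95%.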

Compound 3, a percentage reported as activity, at one concentration (the size of the read-out at that concentration, not a potency): 16%
Beside the measured number, compound 3's estimate is 34 percentage points above it, and the stated range covers the measured number.
By their numbers in this assay, from the lowest: compound 2; then compound 3; then compound 1.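

In this assay the two halogenated rings on the carbonyl carbon are not interchangeable: 3,4-difluorophenyl gives a number 51 percentage points lower from compound 1 to compound 3 (beyond the scatter) against 3,4-dichlorophenyl, so the choice of halogen counts at this position. Even so, it does not match 3,4-dimethoxyphenyl, as a number 97 percentage points higher from compound 2 to compound 3 (beyond the scatter) shows. Nothing available explains either step.

Open, as far as these compounds go, is whether one methoxy group alone would keep the low number of compound 2. Also open, from the compounds shown here alone, is how a hydroxy group or a dimethylamino group would read at this place.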